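A Methoxy Group in Place of Hydrogen on Compound 2

The source may report more compounds than this note shows. Statements on the series, on what has been measured and on what is new or still open speak of the compounds shown alone.

Of the compounds shown here, three sharing one core have been measured. Compound 1 `CCOC(=O)/C=C1/C(=O)Nc2ccccc21`, compound 2 `CC(C)(C)OC(=O)/C=C1/C(=O)Nc2ccccc21` and compound 3 `COc1ccc2c(c1)/C(=C\C(=O)OC(C)(C)C)C(=O)N2` differ from one another only in a single group each. In a functional assay on HepG2 cells (Homo sapiens) for inhibition, read by CCK-8 assay, with a stated time of 72 h, tested at 20 uM (on this read-out lower numbers stand for less inhibition of growth and higher numbers for more inhibition of growth at the one concentration tested), compound 1 gives 90.2%, compound 2 gives 86.1%, and compound 3 gives 90.1%. Compound 2 thus stands lowest of the three numbers, but its nearest neighbour, compound 3, and its furthest, compound 1, both lie within the scatter of it, so no real order among the three can be read. Swapping the ester group gave a number 4.1 percentage points lower from compound 1 to compound 2 (within the scatter), and bringing in a methoxy group gave a number 4 percentage points higher from compound 2 to compound 3 (within the scatter); neither moved the read-out beyond the scatter.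

Compound 4 `COc1ccc2c(c1)NC(=O)/C2=C/C(=O)OC(C)(C)C` is not yet measured. It differs from compound 2 by methoxy in place of hydrogen on an aromatic carbon. For the measured compounds named here, the one measured change of the same kind, a methoxy group entering in place of hydrogen on an aromatic carbon of the core, was a number 4 percentage points higher from compound 2 to compound 3 (within the scatter), within the scatter. On that basis a step of about a number 0.9 percentage points higher from compound 2 to compound 4 (within the scatter) is expected, which is no change beyond the scatter. Compound 4 is therefore estimated to give 87% in this assay, with a likely range from 78% to 95%.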

Compound 4, percent growth inhibition at one concentration: 88.3%
Beside the measured number, compound 4's estimate is 1.3 percentage points below it; low and high end bracket the measured number.
By their numbers in this assay, from the lowest: compounds 2, 4, 3 and 1 (each within the scatter of the next).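

With compound 4, a methoxy group now sits on a second aromatic carbon of the shared core, meta to a fused ring and para to a fused ring, and in this assay this gives a number 2.2 percentage points higher from compound 2 to compound 4 (within the scatter). Compound 3, which carries the same group on a different aromatic carbon, gives 90.1% and compound 4 gives 88.3%; these two values lie within the scatter of each other, so this read-out shows no difference between the two placements of the methoxy group, and neither placement can be told apart from hydrogen. No measurement is available that would explain this lack of separation.

Still open, on these data alone, is whether a different group on these aromatic carbons, such as an amine, a carboxylic acid or a longer chain joined through oxygen, would move the number beyond the scatter. Also open, as far as these compounds go, is whether these closely grouped compounds would separate at concentrations other than the single one tested, or whether changing the amide hydrogen would alter the read-out.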